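The source may hold more compounds than are shown below. What is called first, only, known or untested is meant among the compounds shown, and "the series" means these compounds.

Working notes on the series. Within the data shown here, compound 1 `COc1cccc(OC)c1OCCNCCOc1ccccc1OCc1ccccc1Cl` gives 7.52 in a functional assay on spleen for antagonist activity at Alpha-1B adrenergic receptor (Rattus norvegicus) (a higher number here means a more potent compound, by a factor of ten per unit of this negative logarithm, a lower number a less potent compound), and compound 2 `COc1cccc(OC)c1OCCNCCOc1ccccc1OCc1ccc(Cl)cc1` gives 8.06, the higher of the two numbers so far; the only recorded step, a number 0.54 log units higher from compound 1 to compound 2 (beyond the scatter), is the change from a 2-chlorophenyl to a 4-chlorophenyl group on the chain carbon bound to the aromatic oxygen. Compound 3 `COc1cccc(OC)c1OCCNCCOc1ccccc1OCc1ccccc1C` carries 2-methylphenyl in place of 4-chlorophenyl on a saturated chain carbon bound to an oxygen on an aromatic ring. That step bears on the one recorded, since it moves the substituent back to the position held in compound 1 while also exchanging chlorine for methyl. A drop of about the size of that earlier step is therefore expected, a number 0.46 log units lower from compound 2 to compound 3 (beyond the scatter). Compound 3 is estimated at 7.6, with a range from 7.15 to 8.05.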

Compound 3, negative logarithm of the antagonist equilibrium constant: 7.67
Compound 3: the middle estimate sits 0.07 log units below what was measured; measured number inside the range.
By their numbers in this assay, from the lowest: compounds 1 and 3 (each within the scatter of the next); then compound 2.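

In this assay, methyl in place of chloro on an aromatic carbon gives a number 0.15 log units higher from compound 1 to compound 3 (within the scatter), so these two groups are not separated at this place. The change to 2-methylphenyl from 4-chlorophenyl gives a number 0.39 log units lower from compound 2 to compound 3 (beyond the scatter), which shows that the lower number seen with compound 1 also occurs without chlorine. Nothing on hand explains either step.

On these data alone, whether 4-methylphenyl would match compound 2 remains open, so the role of the substituent's place is not settled for methyl. As far as these compounds go, how unsubstituted phenyl compares with these groups also remains open.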